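The source may report more compounds than this note shows. Statements on the series, on what has been measured and on what is new or still open speak of the compounds shown alone.

Of the compounds shown here, three built on one shared core have been measured in a functional assay on isolated protein for inhibition of Glucose-dependent insulinotropic receptor (Rattus norvegicus), read by HTRF and cAMP accumulation; on this read-out lower numbers stand for smaller maximal responses and higher numbers for larger maximal responses. Compound 1 `Cc1nc(S(C)(=O)=O)ccc1Oc1ncnc(OC2CCN(C(=O)OC(C)(C)C#N)CC2)c1F` gives 97%, compound 2 `Cc1nc(S(C)(=O)=O)ccc1Oc1ncnc(OC2CCN(C(=O)SC3CCC3)CC2)c1F` gives 81%, and compound 3 `Cc1nc(S(C)(=O)=O)ccc1Oc1ncnc(OC2CCN(C(=O)C(C)(F)F)CC2)c1F` gives 87%. Compound 3 stands second highest of the three, but the step of a number 10 percentage points lower from compound 1 to compound 3 (within the scatter) and the step of a number 6 percentage points higher from compound 2 to compound 3 (within the scatter) both lie within the scatter, while only a number 16 percentage points lower from compound 1 to compound 2 (beyond the scatter) lies beyond it. Compound 4 `CCC(F)(F)C(=O)N1CCC(Oc2ncnc(Oc3ccc(S(C)(=O)=O)nc3C)c2F)CC1` differs from compound 3 by methyl in place of hydrogen on a saturated chain carbon, two bonds along the chain from a carbonyl carbon and two fluorine atoms. Within the data shown here, no measured step touches that place; the three measured steps each swap the whole group on the carbonyl carbon, and even the largest of them is modest. A step of a number 2 percentage points lower from compound 3 to compound 4 (within the scatter) is therefore expected in this assay. Compound 4 is estimated at 85%, with a range from 70% to 100%.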

Compound 4, largest response reached (reported as efficacy), in percent of the reference or control that the assay uses: 90%
Compound 4: middle estimate off by 5 percentage points, on the low side; the range from low to high includes it.
By their numbers in this assay, from the lowest: compounds 2, 3, 4 and 1 (each within the scatter of the next, the first and the last beyond it).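

In this assay, among these compounds, methyl in place of hydrogen on this chain carbon gives a number 3 percentage points higher from compound 3 to compound 4 (within the scatter) and so makes no readable difference, the first reading at this place. With 1,1-difluoropropyl on the carbonyl carbon, the swaps give a number 9 percentage points higher from compound 2 to compound 4 (within the scatter) and a number 7 percentage points lower from compound 1 to compound 4 (within the scatter) and so leave compound 4 within the scatter of both other compounds. No available evidence explains these numbers. Going by these compounds, whether a longer chain such as 1,1-difluorobutyl, or an amine on this carbon, would also leave the maximal response unchanged remains open.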